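From 4-Nitrobenzyl to 3-Phenylpropyl on the Sulfur

The source may report more compounds than this note shows. Statements on the series, on what has been measured and on what is new or still open speak of the compounds shown alone.

In a toxicity assay on GES1 cells (Homo sapiens) for inhibition, read by MTT assay, with a stated time of 72 h (a higher number here means a weaker inhibitor, a lower number a stronger inhibitor), compound 3 (`Cc1cc(N2CC[C@@H](C)[C@@H](N(C)c3ncnc4[nH]ccc34)C2)n2nc(SCc3ccc([N+](=O)[O-])cc3)nc2n1`) gives 36600 nM, within the scatter of compound 1 (`Cc1cc(N2CC[C@@H](C)[C@@H](N(C)c3ncnc4[nH]ccc34)C2)n2nc(SCc3ccccc3)nc2n1`) at 67200 nM and of compound 2 (`Cc1cc(N2CC[C@@H](C)[C@@H](N(C)c3ncnc4[nH]ccc34)C2)n2nc(SCCc3ccccc3)nc2n1`) at 66200 nM. Compound 4 (`Cc1cc(N2CC[C@@H](C)[C@@H](N(C)c3ncnc4[nH]ccc34)C2)n2nc(SCCCc3ccccc3)nc2n1`) carries phenethyl in place of 4-nitrophenyl on a saturated chain carbon bound to a sulfur. Among the compounds with values here, three measured steps bear on this change. Extending the chain gave a 1.0-fold lower number from compound 1 to compound 2 (0.01 log units; within the scatter), adding nitro gave a 1.8-fold lower number from compound 1 to compound 3 (0.26 log units; within the scatter), and the closest swap of groups gave a 1.8-fold lower number from compound 2 to compound 3 (0.26 log units; within the scatter). All three are small, so no step beyond the scatter is expected in this assay. The expected step is a 1.6-fold higher number from compound 3 to compound 4 (0.20 log units; within the scatter). For compound 4 the estimated value is 58000 nM, with an expected range of 30000 nM to 100000 nM.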

Compound 4, half-maximal inhibitory concentration: > 100000 nM
Compound 4 gave a limit, no number; the forecaster's own chance of this, stated with the estimate: 15%; middle value at least 1.7-fold (0.23 log units) from the limit.
By their numbers in this assay, from the lowest: compounds 3, 2 and 1 (each within the scatter of the next). At a limit, above all of these: compound 4.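

In this assay the change from 4-nitrobenzyl to 3-phenylpropyl on the sulfur gives an at least 2.7-fold higher number from compound 3 to compound 4 (0.43 log units; beyond the scatter), the only step at this position shown to lie beyond the scatter. The floors of an at least 1.5-fold higher number from compound 2 to compound 4 (0.17 log units; that floor lies within the scatter) and an at least 1.4-fold higher number from compound 1 to compound 4 (0.17 log units; that floor lies within the scatter) lie within the scatter, so they do not yet separate 3-phenylpropyl from the shorter chains. Compound 4 gave a limit of the assay and no number: the limit of > 100000 nM in this assay, at which 1 of the 4 values shown sits. The compounds shown leave open how an amine or a carboxylic acid in place of phenethyl at this position would read, and whether a longer chain would stay at this limit.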